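The source may hold more compounds than are shown below. What is called first, only, known or untested is meant among the compounds shown, and "the series" means these compounds.

Among the measured compounds shown here, compound 2 `N#C/C(=C\N1CCN(C(=O)c2ccco2)C1=S)C(N)=O` gives 34500 nM in a functional assay on A549 cells (Homo sapiens) for inhibition, read by sulforhodamine B assay, with a stated time of 48 h (on this read-out higher numbers stand for weaker inhibition of growth and lower numbers for stronger inhibition of growth), and the only other measured compound, compound 1 `N#C/C(=C\N1CCN(C(=O)c2ccco2)C1=S)C(=O)Nc1ccc(Cl)cc1`, gives 25800 nM, a number within the scatter of that of compound 2. The step of a 1.3-fold higher number from compound 1 to compound 2 (0.13 log units; within the scatter) was a swap of hydrogen for 4-chlorophenyl on an amide-type nitrogen. Compound 3 `N#C/C(=C\N1CCN(C(=O)c2ccco2)C1=S)C(=O)c1ccccc1` differs from compound 2 elsewhere: phenyl in place of amino on a carbonyl carbon. For the measured compounds named here, only that one small step bears on this change, so no movement beyond the scatter in this assay is expected, in either direction; the expected step is a 1.2-fold lower number from compound 2 to compound 3 (0.09 log units; within the scatter). Compound 3 is therefore estimated at 28000 nM, between 8000 nM and 90000 nM.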

Compound 3, concentration for 50% growth inhibition: 22000 nM
The estimate for compound 3 lay 1.3-fold (0.10 log units) above the measured number, and the stated range covers the measured number.
By their numbers in this assay, from the lowest: compounds 3, 1 and 2 (each within the scatter of the next).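

In this assay the swap from amino to phenyl on the carbonyl carbon, which takes away a hydrogen-bond donor and brings in a six-membered aromatic ring, gives a 1.6-fold lower number from compound 2 to compound 3 (0.20 log units; within the scatter) and so stays inside the scatter. Phenyl in place of (4-chlorophenyl)amino on that carbon gives a 1.2-fold lower number from compound 1 to compound 3 (0.07 log units; within the scatter) and so shows the same, which means three quite different groups at this position leave the number unmoved beyond the scatter. Nothing available explains this result. On these data alone, whether a hydroxyl, a methoxy or a longer alkyl chain on this carbonyl carbon would shift the number beyond the scatter remains open.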